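A few compounds are considered here, and "the series" means these few. Any claim that something is new, unique, unknown or untested is made for them only; others in the source may bear on it.

In a functional assay on MDA-MB-453 cells (Homo sapiens) for antiproliferative activity (on this read-out higher numbers stand for weaker inhibition of growth and lower numbers for stronger inhibition of growth), three compounds have been measured:

- Compound 1 `CCCCCCNC(=O)c1cc(C#Cc2cc(OC)ccc2OC)ccc1OC` gives > 100000 nM as a limit of the assay
- Compound 2 `COC(=O)c1cc(/C=C\c2cc(OC)ccc2OC)ccc1OC` gives 10900 nM as a number
- Compound 3 `COc1ccc(OC)c(C#Cc2ccc(OC)c(C(=O)O)c2)c1` gives 8800 nM as a number

Compound 2 and compound 3 lie within the scatter of each other, so neither ranks ahead. The result for compound 1 is a limit and not a number.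

Still to be measured is compound 4 `CCCCCCNC(=O)c1cc(/C=C\c2cc(OC)ccc2OC)ccc1OC` which differs from compound 2 by hexylamino in place of methoxy on a carbonyl carbon with hexylamino in place of methoxy on a carbonyl carbon. Going by the values given here, one measured step bears on this change. It is an at least 11-fold lower number from compound 1 to compound 3 (1.05 log units; beyond the scatter) with hydroxy in place of hexylamino on a carbonyl carbon, a large step beyond the scatter. Read in reverse, that step from compound 1 points to a large rise in this assay on gaining hexylamino. The transfer is uncertain, as the core of compound 1 is not that of compound 2, and hydroxy rather than methoxy is the group exchanged there.

The expected change is a 5.5-fold higher number from compound 2 to compound 4 (0.74 log units; beyond the scatter). The result for compound 4 may turn out to be only a limit of the assay. For compound 4 the estimated value is 60000 nM with an expected range from 20000 nM to 100000 nM.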

Compound 4, concentration for 50% growth inhibition: 10300 nM
The estimate for compound 4 lay 5.8-fold (0.77 log units) above the measured number; the whole stated range lies above it.
By their numbers in this assay, from the lowest: compounds 3, 4 and 2 (each within the scatter of the next). At a limit, above all of these: compound 1.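

In this assay, hexylamino on a carbonyl carbon of the core shared by compound 2 and compound 4 leaves the read-out where it was: a 1.1-fold lower number from compound 2 to compound 4 (0.02 log units; within the scatter). The large step seen earlier, an at least 11-fold lower number from compound 1 to compound 3 (1.05 log units; beyond the scatter), therefore does not carry over to this core, and the methoxycarbonyl to hexylcarbamoyl change brings no loss here. The result for compound 1 remains a limit of the assay and not a number: the limit of > 100000 nM in this assay, at which 1 of the 4 values shown sits.

On these data alone, it remains open how a carboxylic acid in this place would read on the core of compound 2, and whether a shorter or a longer chain than hexyl would keep the read-out of compound 4. Also open, as far as these compounds go, is how far the core of compound 1, rather than hexylamino itself, sets that compound apart.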